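From Phenethyl to Vinyl on the Sulfur Chain

The compounds below may be only part of what the source reports. "The series", "measured", "known", "first", "only" and "open" are said of these compounds alone.

In a functional assay on MCF7 cells (Homo sapiens) for inhibition, read by MTT assay, with a stated time of 72 h (a higher number here means a weaker inhibitor, a lower number a stronger inhibitor), compound 1 (`Cc1cc(Nc2cc(-c3ccccc3)[nH]n2)n2nc(SCc3c(Cl)cccc3Cl)nc2n1`) gives 3230 nM and compound 2 (`Cc1cc(Nc2cc(-c3ccccc3)[nH]n2)n2nc(SCCCc3ccccc3)nc2n1`) gives 3900 nM. For the measured compounds named here, compound 2 stands level with compound 1, as the only measured step, a 1.2-fold higher number from compound 1 to compound 2 (0.08 log units; within the scatter), lies within the scatter. Compound 3 (`C=CCSc1nc2nc(C)cc(Nc3cc(-c4ccccc4)[nH]n3)n2n1`) differs from compound 2 by vinyl in place of phenethyl on a saturated chain carbon bound to a sulfur. The measured step kept an aromatic ring in this group, whereas here the ring leaves, so it guides the expectation only loosely. A modest step to a higher number is expected, a 2.1-fold higher number from compound 2 to compound 3 (0.31 log units; beyond the scatter). Compound 3 is estimated at 8000 nM, with an expected range of 3000 nM to 25000 nM.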

Compound 3, half-maximal inhibitory concentration: > 50000 nM
Compound 3: only a limit was reported; the forecaster's own chance of this, stated with the estimate: 15%; at least 6.2-fold (0.79 log units) between middle value and limit.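

Where the phenethyl and 2,6-dichlorophenyl groups stood level, this position proves far from indifferent: vinyl in their place gives an at least 12-fold higher number from compound 2 to compound 3 (1.10 log units; beyond the scatter) and an at least 15-fold higher number from compound 1 to compound 3 (1.18 log units; beyond the scatter). Among these compounds, only compound 3 lacks an aromatic ring in this group, and its value is a limit, not a number: the limit of > 50000 nM in this assay, at which 1 of the 3 values shown sits.

The compounds shown leave open whether the aromatic ring itself matters or only the size of the group, a question that a hexyl chain or a cyclohexylmethyl group could separate. From the compounds shown here alone, the true value of compound 3 also stays open.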